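The source may report more compounds than this note shows. Statements on the series, on what has been measured and on what is new or still open speak of the compounds shown alone.

Working notes on the series

Of the compounds shown here, two have been measured in an ADME assay (liver) for metabolic stability, with Liver microsome (Rattus norvegicus) as the target, using microsomes and NADPH, with a stated time of 30 min; a higher number here means faster removal of the compound, a lower number slower removal. Compound 1 `CC#C[C@H]1CN(S(=O)(=O)c2ccc(N)nc2)CCN1c1ccc([C@@](O)(CO)C(F)(F)F)cc1` gives 53 mL.min-1.g-1 in this assay. Compound 2 `CC#C[C@H]1CN(S(=O)(=O)c2ccc(N)nc2)CCN1c1ncc(C(O)(C(F)(F)F)C(F)(F)F)s1` gives 34 mL.min-1.g-1 in this assay. On these two numbers compound 1 stands highest, and its nearest neighbour is compound 2, whose number lies within the scatter of repeated measurements; the two values show no separation that can be called a difference.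

Compound 3 `CC#C[C@H]1CN(S(=O)(=O)c2ccc(N)nc2)CCN1c1ccc(S(N)(=O)=O)cc1` has not yet been measured in this assay. It differs from compound 1 in one place: a group of 4 heavy atoms (1 nitrogen, 2 oxygen, 1 sulfur; no ring) in place of a group of 8 heavy atoms (3 carbon, 2 oxygen, 3 fluorine; no ring), on an aromatic carbon. The sulfamoyl group sits on an aromatic carbon of a six-membered aromatic ring of carbon only, para to a large group, where compound 1 carries the group of 8 heavy atoms.

Going by the values given here, no step between measured compounds matches this change, so the expectation rests on the two measured values only. The step from compound 1 to compound 3 is expected to be moderate and downward, a 2.1-fold lower number from compound 1 to compound 3 (0.33 log units; beyond the scatter), though it may fall within the scatter. Compound 3 is estimated at 25 mL.min-1.g-1 in this assay, with a range from 10 mL.min-1.g-1 to 60 mL.min-1.g-1.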

Compound 3, intrinsic clearance in microsomes: 30 mL.min-1.g-1
Compound 3: middle estimate off by 1.2-fold (0.08 log units), on the low side, and the stated range covers the measured number.
By their numbers in this assay, from the lowest: compounds 3, 2 and 1 (each within the scatter of the next).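

The series now has its first readable step between compounds that differ in one place: in this assay, sulfamoyl in place of the group of 8 heavy atoms, on an aromatic carbon of a six-membered aromatic ring of carbon only and para to a large group, gives a 1.8-fold lower number from compound 1 to compound 3 (0.25 log units; within the scatter) and no separation that can be called a difference. At this position, then, the change in heavy-atom count, the absence of fluorine and the absence of the defined stereocentre together leave the intrinsic clearance of compound 3 indistinguishable from that of compound 1. No measurement of any property of these groups is available to bear on this result.

Going by these compounds, whether a carboxylic acid, an amine or a longer chain at the same place would give a step beyond the scatter remains open. Also open, on these data alone, is which part of the group of 8 heavy atoms, if any, contributes to the number for compound 1, since this single step replaces the whole group at once.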